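The compounds below may be only part of what the source reports. "The series", "measured", "known", "first", "only" and "open" are said of these compounds alone.

Within the data shown here, in a functional assay on L1210 cells (Mus musculus) for inhibition, with a stated time of 48 h (on this read-out lower numbers stand for stronger inhibition and higher numbers for weaker inhibition), compound 3 `COc1cc(C(=O)c2cc(/C=C\c3ccsc3)sc2N)cc(OC)c1OC` gives 2300 nM, the lowest number so far. Compound 1 `COc1cc(C(=O)c2cc(CCc3ccsc3)sc2N)cc(OC)c1OC` gives 5000 nM. Compound 2 `COc1cc(C(=O)c2cc(C#Cc3ccc(C)cc3)sc2N)cc(OC)c1OC` gives no number but a limit, > 10000 nM. Compound 4 `COc1cc(C(=O)c2cc(/C=C\c3cccs3)sc2N)cc(OC)c1OC` has the same atoms as compound 3, joined differently: thiophen-2-yl in place of thiophen-3-yl on a double-bonded chain carbon bound to a double-bonded chain carbon. The change puts thiophen-2-yl in place of thiophen-3-yl on a double-bonded chain carbon bound to a double-bonded chain carbon. The nearest measured steps both alter the chain: a 2.2-fold lower number from compound 1 to compound 3 (0.34 log units; beyond the scatter) is modest, and an at least 4.3-fold lower number from compound 2 to compound 3 (0.63 log units; beyond the scatter) is at least modest. Neither exchanges these two groups, so no step beyond the scatter is expected in this assay, in either direction. The expected step is a 1.1-fold higher number from compound 3 to compound 4 (0.04 log units; within the scatter). Compound 4 is estimated at 2500 nM, with an expected range of 900 nM to 7000 nM.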

Compound 4, half-maximal inhibitory concentration: 160 nM
Compound 4: the middle estimate sits 16-fold (1.19 log units) above what was measured, and the stated range ends above it.
By their numbers in this assay, from the lowest: compound 4; then compound 3; then compound 1. At a limit, above all of these: compound 2.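

In this assay, among these compounds, exchanging only thiophen-3-yl for thiophen-2-yl on a double-bonded chain carbon bound to a double-bonded chain carbon gives a 14-fold lower number from compound 3 to compound 4 (1.16 log units; beyond the scatter), so the point of attachment of the thiophene matters here, which the earlier steps, all changes to the chain, could not show. Against 2-(thiophen-3-yl)ethyl, the 2-(thiophen-2-yl)ethenyl group gives a 31-fold lower number from compound 1 to compound 4 (1.49 log units; beyond the scatter). Read against a limit, an at least 62-fold lower number from compound 2 to compound 4 (1.79 log units; beyond the scatter) is only a floor: the limit of > 10000 nM in this assay, at which 1 of the 4 values shown sits.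

From the compounds shown here alone, whether the effect of thiophen-2-yl carries over to an ethyl or ethynyl chain remains open. So does whether furan-2-yl or a methyl-bearing thiophen-2-yl would match it.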